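From dimethylamino to amino at compound 4

The compounds below may be only part of what the source reports. "The series", "measured", "known", "first", "only" and "open" are said of these compounds alone.

In a functional assay on HCT-116 cells (Homo sapiens) for antiproliferative activity, read by MTT assay, with a stated time of 48 h (on this read-out higher numbers stand for weaker inhibition and lower numbers for stronger inhibition), compound 1 (`CCCCCCCCC(CCO)n1cnc2c(N)ncnc21`) gives 11600 nM, compound 2 (`CCCCCCCCCC(CCO)n1cnc2c(OC)ncnc21`) gives 2530 nM, and compound 3 (`CCCCCCCCCC(CCO)n1cnc2c(N(C)C)ncnc21`) gives 9810 nM. Compound 3 therefore lies within the scatter of compound 1 and clearly apart from compound 2, the methoxy member.

Next is compound 4 (`CCCCCCCCCC(CCO)n1cnc2c(N)ncnc21`), which keeps the chain of compound 3 and carries one change: amino in place of dimethylamino on an aromatic carbon. That is amino in place of dimethylamino on an aromatic carbon.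

For the measured compounds named here, only one measured step involves this carbon: a 3.9-fold higher number from compound 2 to compound 3 (0.59 log units; beyond the scatter). It is modest but beyond the scatter, so a swap here can move the number. However, it replaces methoxy, not amino, and so does not size the present change directly.

The closest reference is compound 1, which already has the amino group on a shorter chain and gives 11600 nM. That value is within the scatter of compound 3, so no step beyond the scatter is expected in this assay. The expected change is a 1.2-fold lower number from compound 3 to compound 4 (0.06 log units; within the scatter).

For compound 4 the estimated value is 8500 nM, with an expected range of 4000 nM to 17000 nM.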

Compound 4, half-maximal inhibitory concentration: 10500 nM
Beside the measured number, compound 4's estimate is 1.2-fold (0.09 log units) below it; measured number inside the range.
By their numbers in this assay, from the lowest: compound 2; then compounds 3, 4 and 1 (each within the scatter of the next).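

In this assay, amino and dimethylamino on this aromatic carbon cannot be told apart (a 1.1-fold higher number from compound 3 to compound 4 (0.03 log units; within the scatter)), so the two methyl groups of dimethylamino carry no measurable weight in these numbers. Compound 4 also gives the direct comparison of amino with methoxy on this carbon (a 4.2-fold higher number from compound 2 to compound 4 (0.62 log units; beyond the scatter)), and with the step from compound 2 to compound 3 (a 3.9-fold higher number from compound 2 to compound 3 (0.59 log units; beyond the scatter)), it leaves methoxy as the only group shown here that stands apart from the nitrogen-linked groups on this chain. For the compounds shown here, the first direct reading of the chain end shows that methyl in place of hydrogen on a saturated chain carbon, nine bonds along the chain from an aromatic nitrogen, also stays within the scatter (a 1.1-fold lower number from compound 1 to compound 4 (0.04 log units; within the scatter)), at least with amino on the aromatic carbon.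

Nothing in hand explains why methoxy separates from amino and dimethylamino. Still open, from the compounds shown here alone, are whether an ethoxy group, a chlorine or a morpholine on this aromatic carbon would track with methoxy or with the amines, and whether a much longer chain, or a carboxylic acid in place of the terminal hydroxyl, would shift the numbers.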